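Hydrazone urea series: replacing the nitrophenyl arm

The compounds below may be only part of what the source reports. "The series", "measured", "known", "first", "only" and "open" are said of these compounds alone.

Measured compounds in a functional assay on HepG2 cells (Homo sapiens) for antiproliferative activity, read by MTT assay, with a stated time of 72 h; a lower number here means a stronger inhibitor, a higher number a weaker inhibitor:
- compound 1 `O=C(N/N=C/c1cccc([N+](=O)[O-])c1)Nc1ccc(Oc2ccnc3[nH]ccc23)c(F)c1`: 5180 nM
- compound 2 `O=C(N/N=C/c1ccccc1)Nc1ccc(Oc2ccnc3[nH]ccc23)cc1`: 750 nM
- compound 3 `COc1ccc(/C=N/NC(=O)Nc2ccc(Oc3ccnc4[nH]ccc34)cc2)cc1`: 9740 nM

Compound 1 gives the second highest of the three numbers. Its nearest neighbour is compound 3, whose value lies within the scatter of it, so no order between the two can be stated. Compound 2 gives a number well below that of compound 1, beyond the scatter.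

Compound 4 `CN(C)CCn1cccc1/C=N/NC(=O)Nc1ccc(Oc2ccnc3[nH]ccc23)c(F)c1` is not yet measured. Relative to compound 1 the change is 1-(2-(dimethylamino)ethyl)-1H-pyrrol-2-yl in place of 3-nitrophenyl on a carbon with a double bond to nitrogen. Compound 1 and compound 4 share the rest of the structure, including the fluorine on the aryl urea.

Within the data shown here, the only measured step that bears on the hydrazone aryl arm is a 13-fold higher number from compound 2 to compound 3 (1.11 log units; beyond the scatter), which shows that a single change on that arm can move the number by a large margin. Among the measured compounds shown here, no measured pair covers an exchange of the whole aromatic group, nor the entry of the 1-(2-(dimethylamino)ethyl)-1H-pyrrol-2-yl group, so the direction for compound 4 cannot be read from the data. The expectation is therefore a step of uncertain direction, with a wide range.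

Compound 4 is estimated at 3000 nM (range 600 nM to 15000 nM), which would mean an expected step of a 1.7-fold lower number from compound 1 to compound 4 (0.24 log units; within the scatter).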

Compound 4, half-maximal inhibitory concentration: 8980 nM
The estimate for compound 4 lay 3.0-fold (0.48 log units) below the measured number; the range from low to high includes it.
By their numbers in this assay, from the lowest: compound 2; then compounds 1, 4 and 3 (each within the scatter of the next).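

In this assay, 1-(2-(dimethylamino)ethyl)-1H-pyrrol-2-yl in place of 3-nitrophenyl on a carbon with a double bond to nitrogen gives a 1.7-fold higher number from compound 1 to compound 4 (0.24 log units; within the scatter), so no order can be stated between the two compounds. Among these compounds, the earlier compounds showed only that a single change on this arm can be large, as in a 13-fold higher number from compound 2 to compound 3 (1.11 log units; beyond the scatter); this result adds that exchanging the whole aromatic group, a six-membered carbon ring for a five-membered ring with one hetero atom and a side chain, need not move the number beyond the scatter when the fluorine on the aryl urea is present. No measurement at hand gives a reason for the size of either step.

As far as these compounds go, compound 1 and compound 2 differ in both the hydrazone arm and the fluorine, so the contribution of each to the gap between their printed values cannot be separated, and it remains open whether either arm would behave the same way without the fluorine. Also open, from the compounds shown here alone, is whether the pyrrole without its side chain, or with a morpholine in place of the dimethylamino group, would give a number apart from that of compound 4.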